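This account rests on a few compounds, and the source may have more. Where it says the series, first, only, none or still open, it means among the compounds named here.

Series notes. The set comprises compound 1 `Cc1cc(NC(=O)Nc2ccc(Cl)c(Cl)c2)c2ccccc2n1`, compound 2 `CSc1ccc(NC(=O)Nc2cc(C)nc3ccccc23)cc1`, compound 3 `Cc1cc(NC(=O)Nc2ccccc2N)c2ccccc2n1` and, not yet measured, compound 4 `Cc1cc(NC(=O)Nc2ccc(C(=O)O)cc2)c2ccccc2n1`. In an ADME assay on HEK293 cells (Homo sapiens) for cytotoxicity, with a stated time of 72 h (a higher number here means that more compound is needed for the effect, a lower number that less compound is needed), compound 1 gives > 25000 nM, which is a limit of the assay and not a number. Compound 3 likewise gives > 25000 nM in this assay, again a limit. Among the measured compounds shown here, compound 2 is the only member with an actual number, 24000 nM in this assay, and that number sits close to the limit of > 25000 nM in this assay, at which 2 of the 3 values shown sit. Compound 4 differs from compound 2 by carboxy in place of methylsulfanyl on an aromatic carbon. For the measured compounds named here, with no measured step in the set to lean on, the working expectation in this assay is a step of a 1.3-fold higher number from compound 2 to compound 4 (0.10 log units; within the scatter), at most a drift toward the limit and nothing beyond the scatter. Compound 4 is accordingly estimated at 30000 nM, within 10000 nM to 100000 nM.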

Compound 4, half-maximal effective concentration: > 25000 nM
Compound 4 was reported as a limit; the forecaster's own chance of this, stated with the estimate: 70%; the middle value lies beyond the limit too.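

In this assay, carboxy in place of methylsulfanyl on an aromatic carbon, para to a large group, gives an at least 1.0-fold higher number from compound 2 to compound 4 (0.01 log units; that floor lies within the scatter). Among the compounds shown here, this is the first comparison at one position: the change adds a hydrogen-bond donor there, and no lower number appears, though the true size of the step cannot be read. The read-out is capped at this position: the limit of > 25000 nM in this assay, at which 3 of the 4 values shown sit.

On these data alone, whether any group here can bring the number clearly down stays open. A nitrile or a longer chain at this position would test that.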